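Oxadiazole in place of the amide on the shared core

The source may report more compounds than this note shows. Statements on the series, on what has been measured and on what is new or still open speak of the compounds shown alone.

Compound 1 `CCN(CC)C(=O)[C@@H]1CCCN(S(=O)(=O)c2ccc(S(=O)(=O)N(CC)CC)cc2)C1` carries a diethylcarbamoyl group on a saturated ring carbon of the shared core. In a functional assay on MIA PaCa-2 cells (Homo sapiens) for inhibition, read by MTT assay, with a stated time of 3 days (a higher number here means a weaker inhibitor, a lower number a stronger inhibitor), compound 1 gives only a limit, > 10000 nM. Compound 2 `CCN(CC)S(=O)(=O)c1ccc(S(=O)(=O)N2CCC[C@@H](C(=O)NC3CN(C(=O)NC(C)(C)C)C3)C2)cc1` and compound 3 `CCN(CC)S(=O)(=O)c1ccc(S(=O)(=O)N2CCC[C@@H](C(=O)N3CCN(c4nc(C)no4)CC3)C2)cc1` vary the group on that carbonyl carbon. In this assay compound 2 gives only a limit, > 10000 nM. Compound 3 likewise gives only a limit, > 10000 nM. Going by the values given here, the steps a step that the two limits leave unreadable from compound 1 to compound 2, a step that the two limits leave unreadable from compound 1 to compound 3 and a step that the two limits leave unreadable from compound 2 to compound 3 are therefore unreadable, and the limit of > 10000 nM in this assay, at which 3 of the 3 values shown sit, sums up the position: every value so far sits at the limit, so compound 1 stands nowhere on a scale of numbers, only at that limit.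

Compound 4 `CCN(CC)S(=O)(=O)c1ccc(S(=O)(=O)N2CCC[C@@H](c3nc(C)no3)C2)cc1` differs from compound 1 by 3-methyl-1,2,4-oxadiazol-5-yl in place of diethylcarbamoyl on a saturated ring carbon. Among the compounds with values here, no measured step bears directly on this change: the measured steps from compound 1 all alter the group attached to the carbonyl carbon and keep the carbonyl, whereas here the carbonyl itself leaves and an aromatic ring enters in its place. With three compounds at the limit and no readable step, no direction can be read off, and a step of no readable size is expected, a step that the limit leaves unreadable from compound 1 to compound 4. Compound 4 is expected to give 15000 nM, most likely again a limit, within 4000 nM to 60000 nM.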

Compound 4, half-maximal inhibitory concentration: > 10000 nM
Compound 4: a limit, no number; the forecaster's own chance of this, stated with the estimate: 80%; the middle value does not contradict the limit.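

In this assay compound 4 gives > 10000 nM, a limit and not a number. Going by these compounds alone, compound 1 and compound 4 thus both stand at a limit, and no step between them can be read. Whether any group shown on the shared core alters inhibition stays open, with no compound yet giving a number: the limit of > 10000 nM in this assay, at which 4 of the 4 values shown sit.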